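The source may report more compounds than this note shows. Statements on the series, on what has been measured and on what is new or still open speak of the compounds shown alone.

In an assay on isolated protein for displacement of a labelled ligand from D(4) dopamine receptor (Homo sapiens), tested at 1 uM (on this read-out higher numbers stand for more inhibition at the one concentration tested (going by the name of the read-out) and lower numbers for less inhibition), compound 2 `O=C(NC1CCN(Cc2ccccc2Cl)CC1)c1ccc2ccccc2c1` gives 48%, the higher of the two numbers in hand. Among the measured compounds shown here, compound 1 `O=C(NC1CCN(Cc2ccccc2Br)CC1)c1cccc2ccccc12` gives 35% in this assay, a number below compound 2 by more than the usual scatter; the two compounds differ in more than one place, so no single step is drawn between them. Compound 3 `O=C(NC1CCN(Cc2ccccc2Br)CC1)c1ccc2ccccc2c1` is not yet measured. Its change from compound 2 is bromo in place of chloro on an aromatic carbon. Nothing in the measured pair isolates this exchange, and the expected step is a number 1 percentage points lower from compound 2 to compound 3 (within the scatter), nothing beyond the scatter. Compound 3 is therefore estimated at 47% in this assay, between 30% and 62%.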

Compound 3, a percentage reported as inhibition, at one concentration (the size of the read-out at that concentration, not a potency): 31%
For compound 3 the middle estimate is 16 percentage points above the measured one, and the stated range covers the measured number.
By their numbers in this assay, from the lowest: compounds 3 and 1 (each within the scatter of the next); then compound 2.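

Bromo in place of chloro on an aromatic carbon, ortho to a large group, gives a number 17 percentage points lower from compound 2 to compound 3 (beyond the scatter) in this assay and so provides the first comparison in which only one place differs. This position therefore responds to the halogen, although one heavy atom replaces one heavy atom and the counts of hydrogen-bond donors and acceptors and the net charge stay the same. Nothing at hand explains the step.

From the compounds shown here alone, whether fluoro, methyl or methoxy on this carbon would stand nearer chloro or bromo remains open. Going by these compounds, it is also open whether the same exchange gives a similar step on the core of compound 1.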